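Shortening the ester chain on a shared benzimidazole-type core

This account rests on a few compounds, and the source may have more. Where it says the series, first, only, none or still open, it means among the compounds named here.

Of the compounds shown here, two with a shared core have been measured. Compound 1 `O=C(Nc1nc2cc(C(=O)OCC3CC3)ccc2[nH]1)OCC1CC1` gives 2200 nM in a functional assay on L1210 cells (Mus musculus) for inhibition; a lower number here means a stronger inhibitor, a higher number a weaker inhibitor. Compound 2 `COC(=O)Nc1nc2cc(C(=O)OCCC(C)CC(C)(C)C)ccc2[nH]1` gives 740 nM in this assay, the lowest of the two numbers and a gap beyond the usual scatter from compound 1, so compound 2 counts as the stronger inhibitor of the pair.

Compound 3 `COC(=O)Nc1nc2cc(C(=O)OCC3CC3)ccc2[nH]1` has not yet been measured. It differs from compound 2 in one place: cyclopropyl in place of 2,4,4-trimethylpentyl on a saturated chain carbon bound to an oxygen next to a carbonyl group. In words, a branched eight-carbon chain is exchanged for a small three-membered ring on the same saturated chain carbon. Among the compounds with values here, no measured pair shows this exact exchange alone, so the size of the step cannot be read from a known case. Compound 1, which also carries the cyclopropyl group at this place, shows the higher number of the two, and the expectation is that compound 3 moves in that direction. The estimated step from compound 2 to compound 3 is a 2.0-fold higher number from compound 2 to compound 3 (0.31 log units; beyond the scatter), a modest loss in potency. Compound 3 is expected to give about 1500 nM, with a likely range from 500 nM to 5000 nM.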

Compound 3, half-maximal inhibitory concentration: 6900 nM
Compound 3: the middle estimate sits 4.6-fold (0.66 log units) below what was measured; the whole stated range lies below it.
By their numbers in this assay, from the lowest: compound 2; then compound 1; then compound 3.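

Exchanging 2,4,4-trimethylpentyl for cyclopropyl on a saturated chain carbon bound to an oxygen next to a carbonyl group gives a 9.3-fold higher number from compound 2 to compound 3 (0.97 log units; beyond the scatter) in this assay, so the size of this change now rests on a measured pair, and the compound with the larger chain is the stronger inhibitor. A separate single change, hydrogen in place of cyclopropyl on a carbon of the same description, gives a 3.1-fold higher number from compound 1 to compound 3 (0.50 log units; beyond the scatter), so losing the cyclopropyl group there also weakens inhibition, and in both pairs compound 3 carries the smaller group and gives the higher number. Nothing available explains why either change moves the number in this direction.

What the compounds leave open is how the number changes between the two chains at the first place: a straight hexyl chain would help separate the effect of chain length from that of branching. A chain ending in an amine or a carboxylic acid would test whether a carbon-only group is needed there at all.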